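The source may hold more compounds than are shown below. What is called first, only, known or untested is meant among the compounds shown, and "the series" means these compounds.

Working notes on the series.

Compound 1 `COC(=O)[C@@]1(C)CCC=C2[C@@H]1CC[C@@H](C)[C@]2(C)Cc1c[nH]c2ccc(C)cc12` and compound 2 `COC(=O)[C@@]1(C)CCC=C2[C@@H]1CC[C@@H](C)[C@]2(C)Cc1c[nH]c2ccc(Br)cc12` share one core; compound 3 `COC(=O)[C@@]1(C)CCC=C2[C@@H]1CC[C@@H](C)[C@]2(C)Cc1c(C)[nH]c2c(C)cccc12` and compound 4 `COC(=O)[C@@]1(C)CCC=C2[C@@H]1CC[C@@H](C)[C@]2(C)Cc1c(C)[nH]c2c(Br)cccc12` share another. How the core of compound 1 and the core of compound 3 differ is not broken down here. In a functional assay on HBL-100 cells (Homo sapiens) for inhibition, read by sulforhodamine B assay, with a stated time of 48 h (on this read-out higher numbers stand for weaker inhibition of growth and lower numbers for stronger inhibition of growth), compound 1 gives 18000 nM, compound 2 gives 16000 nM and compound 3 gives 16000 nM; all three numbers lie within the scatter of one another, so no order is drawn among them.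

Going by the values given here, the only measured single-point change is bromo in place of methyl on an aromatic carbon, which gave a 1.1-fold lower number from compound 1 to compound 2 (0.05 log units; within the scatter). The change from compound 3 to compound 4 is bromo in place of methyl on an aromatic carbon. It is the same kind of change, not the same: in compound 2 the bromo sits meta to a fused ring and para to a fused ring, while in compound 4 it sits ortho to a fused ring and meta to a fused ring.

With one prior example of this kind of change showing no movement, compound 4 is expected to stay close to compound 3, an estimated 1.1-fold lower number from compound 3 to compound 4 (0.03 log units; within the scatter) in this assay, resting on the flat step a 1.1-fold lower number from compound 1 to compound 2 (0.05 log units; within the scatter). The estimate for compound 4 is 15000 nM, between 7000 nM and 32000 nM.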

Compound 4, concentration for 50% growth inhibition: 27000 nM
The estimate for compound 4 lay 1.8-fold (0.26 log units) below the measured number; the measured number falls inside the stated range.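

In this assay, bromo in place of methyl on an aromatic carbon gives a 1.7-fold higher number from compound 3 to compound 4 (0.23 log units; within the scatter). Set beside the earlier step, the change does not separate the two cores: the same change on two cores in this assay, a 1.1-fold lower number (0.05 log units; within the scatter) from compound 1 to compound 2 and a 1.7-fold higher number (0.23 log units; within the scatter) from compound 3 to compound 4, 1.9-fold (0.28 log units) apart, within the scatter of two such steps. This shows that the step stays within the scatter on both cores, even with the bromo placed differently on the aromatic ring, but it does not show that the change carries over identically, and two steps cannot separate the contribution of the core from that of the place.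

All four compounds keep the methyl ester and carry only methyl or bromo at the varied aromatic carbon, leaving open what a carboxylic acid in place of the ester, or an amine or a methoxy group on that carbon, would do to growth inhibition. Also open, going by these compounds, is whether bromo and methyl stay level at other places on the aromatic ring of either core.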